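Fused sulfone series: aminopropyl chain on the saturated ring

This account rests on a few compounds, and the source may have more. Where it says the series, first, only, none or still open, it means among the compounds named here.

Compound 1 `O=C(Nc1ccc2c(c1)S(=O)(=O)CC2)c1cc([N+](=O)[O-])c(Sc2c(Cl)cncc2Cl)s1` is the reference point of this set. In an assay on isolated protein for inhibition of ubiquitin carboxyl-terminal hydrolase 7 (Homo sapiens) (on this read-out higher numbers stand for weaker inhibition and lower numbers for stronger inhibition), compound 1 gives 130 nM. Compound 2 `O=C(Nc1ccc2c(c1)S(=O)(=O)C=C2)c1cc([N+](=O)[O-])c(Sc2c(Cl)cncc2Cl)s1` differs from compound 1 only within the fused non-aromatic ring; in this assay compound 2 gives 100 nM, and the two values lie within the usual scatter, so no order between them is claimed. Compound 3 `CC(=O)c1cnc(Sc2c(Cl)cncc2Cl)s1`, a much smaller structure that keeps only part of the shared core, gives 22600 nM in this assay; against this number compound 1 stands far lower, and that gap is beyond the scatter. Among the three numbers compound 1 stands second highest.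

Compound 4 `CN(C)CCCNC1CS(=O)(=O)c2cc(NC(=O)c3cc([N+](=O)[O-])c(Sc4c(Cl)cncc4Cl)s3)ccc21` is the next step from compound 1: (3-(dimethylamino)propyl)amino in place of hydrogen on a saturated ring carbon. Going by the values given here, no step between measured compounds isolates a change of this kind, so the expectation rests on compound 1 alone, with its value of 130 nM in this assay, and the rest of the structure unchanged. The step from compound 1 to compound 4 is expected to be small, a 1.2-fold lower number from compound 1 to compound 4 (0.07 log units; within the scatter), not beyond the scatter in either direction. Compound 4 is therefore estimated at 110 nM, with a range from 30 nM to 400 nM.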

Compound 4, half-maximal inhibitory concentration: 200 nM
Estimate against measurement, compound 4: 1.8-fold (0.26 log units) below; low and high end bracket the measured number.
By their numbers in this assay, from the lowest: compounds 2, 1 and 4 (each within the scatter of the next); then compound 3.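

The saturated ring carbon two ring bonds from the ring sulfur takes (3-(dimethylamino)propyl)amino in place of hydrogen in this assay with a 1.5-fold higher number from compound 1 to compound 4 (0.19 log units; within the scatter) and so without a readable loss or gain. Going by these compounds alone, this is the first look at substitution on this ring carbon, and it shows that a chain of this size can sit there while the number stays within the scatter of that of compound 1. It remains a single step at a single place and sets no pattern, and no measurement here bears on why the value holds.

Open, going by these compounds, is whether a shorter chain, a longer chain or a carboxylic acid on the same ring carbon would leave the number equally unmoved. A morpholine ring or a primary amine in place of the dimethylamino end would show whether that end matters at all.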